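Thiazole for Pyrimidine on a Spirocyclic Orexin-2 Antagonist Core

The compounds below may be only part of what the source reports. "The series", "measured", "known", "first", "only" and "open" are said of these compounds alone.

Three compounds have been measured in a functional assay on HEK293 cells for antagonist activity at Orexin receptor type 2 (Homo sapiens), read by FLIPR and calcium flux; a lower number here means a less potent compound, a higher number a more potent compound, by a factor of ten per unit of this negative logarithm:

compound 1, `Cc1cnn(-c2ccc(C)nc2C(=O)N2CC3(CC3)C[C@H]2CNc2ccc(C(F)(F)F)cn2)c1`: 8.3
compound 2, `Cc1ccc(-c2ncccn2)c(C(=O)N2CC3(CC3)C[C@H]2CNc2ccc(C(F)(F)F)cn2)n1`: 7.5
compound 3, `O=C(c1ncccc1-c1ncccn1)N1CC2(CC2)C[C@H]1CNc1ccc(C(F)(F)F)cn1`: 5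

Compound 2 sits second of the three. Its nearest neighbour is compound 1, which lies higher: the change is a number 0.80 log units lower from compound 1 to compound 2 (beyond the scatter). Its furthest neighbour is compound 3, and that gap is a number 2.50 log units lower from compound 2 to compound 3 (beyond the scatter), so the methyl on the aromatic ring matters a great deal in this assay.

Compound 4, `Cc1ccc(-c2nccs2)c(C(=O)N2CC3(CC3)C[C@H]2CNc2ccc(C(F)(F)F)cn2)n1`, keeps that methyl and the rest of the shared core, and changes only the aryl group: 1,3-thiazol-2-yl in place of pyrimidin-2-yl on an aromatic carbon. Going by the values given here, only one measured step bears on this kind of exchange, the swap of the aryl group that separates compound 1 from compound 2, a number 0.80 log units lower from compound 1 to compound 2 (beyond the scatter), which was modest. Among the compounds with values here, no thiazole analogue has been measured, so the direction for compound 4 is uncertain; both a small loss and a small gain against compound 2 are plausible, and the sensitive methyl is retained.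

Compound 4 is therefore expected to land near compound 2, with an estimated step of a number 0.20 log units higher from compound 2 to compound 4 (within the scatter) in this assay. The estimate for compound 4 is 7.7, within a range from 7 to 8.4.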

Compound 4, negative logarithm of the antagonist equilibrium constant: 8
Compound 4: middle estimate off by 0.30 log units, on the low side, within the range that was stated.
By their numbers in this assay, from the lowest: compound 3; then compound 2; then compounds 4 and 1 (each within the scatter of the next).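

Exchanging the six-membered pyrimidin-2-yl for the five-membered 1,3-thiazol-2-yl on this aromatic carbon gives a number 0.50 log units higher from compound 2 to compound 4 (beyond the scatter) in this assay, so the position responds to this exchange even though the counts of hydrogen-bond donors and acceptors stay the same. The comparison with the pyrazole analogue gives a number 0.30 log units lower from compound 1 to compound 4 (within the scatter), which means that 1,3-thiazol-2-yl and 4-methyl-1H-pyrazol-1-yl cannot be told apart here, and among the three groups shown at this position only pyrimidin-2-yl stands apart from the other two by more than the scatter. No measurement shown here explains the difference between the two rings, so the data record the step without accounting for it.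

The compounds shown leave open whether a plain phenyl ring or a dimethylamino group on this carbon would keep the number at this level. They also leave open whether the methyl group, whose removal gives a number 2.50 log units lower from compound 2 to compound 3 (beyond the scatter) in the pyrimidine series, matters to the same extent when 1,3-thiazol-2-yl occupies this position.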